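The compounds below may be only part of what the source reports. "The series", "measured", "known", "first", "only" and "open" are said of these compounds alone.

Working notes on the series. Going by the values given here, compound 1 `COc1ccc(/C=C2/CN(C)/C(=N/c3ccc(C)cc3)S2)cc1` is the reference point: in a functional assay on HCT-116 cells (Homo sapiens) for antiproliferative activity, read by MTT assay, with a stated time of 72 h (on this read-out lower numbers stand for stronger inhibition and higher numbers for weaker inhibition), compound 1 gives 11100 nM, the only actual number among the three values shown. Compound 2 `C=C1CN/C(=N/c2ccccc2)S1` reaches only a limit of this assay, recorded as > 100000 nM. Compound 3 `COc1ccc(/C=C2\S/C(=N\c3ccc(OC)cc3)N(C)C2=O)cc1` likewise reaches only a limit, recorded as > 100000 nM. Among the compounds with values here, the remaining evidence is thus (the limit of > 100000 nM in this assay, at which 2 of the 3 values shown sit), so no step between measured compounds can be sized, and compound 1 stands alone as the one compound with a read number.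

Compound 4 `COc1ccc(/C=C2/CN(C)/C(=N/c3ccc([N+](=O)[O-])cc3)S2)cc1` is still to be measured. It differs from compound 1 by nitro in place of methyl on an aromatic carbon. Within the data shown here, with no measured step to lean on, the expectation in this assay is a step of modest size at most, and the step from compound 1 to compound 4 is expected to remain within the scatter, a 1.2-fold lower number from compound 1 to compound 4 (0.09 log units; within the scatter). Compound 4 is expected to give about 9000 nM, with a range from 2500 nM to 35000 nM.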

Compound 4, half-maximal inhibitory concentration: 10200 nM
Estimate against measurement, compound 4: 1.1-fold (0.05 log units) below; measured number inside the range.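

In this assay, going by these compounds alone, the first step that can be sized at this position is a 1.1-fold lower number from compound 1 to compound 4 (0.04 log units; within the scatter). Nitro in place of methyl on an aromatic carbon, para to a large group, therefore leaves the read-out within the scatter, even though the entering group has hydrogen-bond acceptors and the leaving group has none. No measured evidence shown here bears on a cause for this result.

Steps to compound 2 and compound 3 cannot be read, so this single pair carries all that is known about the position and supports no trend. Open, from the compounds shown here alone, is whether an amine, a carboxylic acid or a longer alkyl chain at the same position would also stay within the scatter of compound 1, or would move the read-out beyond it.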